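Turning One Stereocentre in the Side Chain

The source may report more compounds than this note shows. Statements on the series, on what has been measured and on what is new or still open speak of the compounds shown alone.

Compound 1 `CC(C)=CC[C@@H](OC[C@H](C)O)C1=CC(=O)c2c(O)ccc(O)c2C1=O`: 40300 nM
Compound 2 `CC(C)=CC[C@@H](OC(=O)c1ccco1)C1=CC(=O)c2c(O)ccc(O)c2C1=O`: 80300 nM

Going by the values given here, in a functional assay on HeLa cells (Homo sapiens) for cytotoxicity, read by MTT assay (on this read-out higher numbers stand for weaker inhibition and lower numbers for stronger inhibition), compound 1 gives 40300 nM, and only one other measured compound is available for comparison. Replacing the 2-hydroxypropyl group with (furan-2-yl)carbonyl gave a 2.0-fold higher number from compound 1 to compound 2 (0.30 log units; within the scatter), so these two values cannot be told apart.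

Compound 3 `CC(C)=CC[C@@H](OC[C@@H](C)O)C1=CC(=O)c2c(O)ccc(O)c2C1=O` is closely related to compound 1: the two compounds have the same atoms and bonds and differ only in configuration as drawn: 1 of 2 stereo elements differ; a stereocentre at a saturated chain carbon is drawn S in compound 1 and R in compound 3. Among the compounds with values here, no measured step tests a change of configuration, so the data offer no direct guide. Within the data shown here, the only available step exchanged a whole group without leaving the scatter, and this change alters far less of the structure, although a single stereocentre can sometimes matter. No shift beyond the scatter is therefore expected in either direction. The expected change is a 1.1-fold higher number from compound 1 to compound 3 (0.05 log units; within the scatter). The estimated value for compound 3 is 45000 nM, with an expected range of 20000 nM to 95000 nM.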

Compound 3, half-maximal inhibitory concentration: 22500 nM
Compound 3: middle estimate off by 2.0-fold (0.30 log units), on the high side; low and high end bracket the measured number.
By their numbers in this assay, from the lowest: compounds 3, 1 and 2 (each within the scatter of the next, the first and the last beyond it).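

In this assay, turning the stereocentre at the saturated chain carbon from S to R gives a 1.8-fold lower number from compound 1 to compound 3 (0.25 log units; within the scatter), so this read-out does not separate the two configurations. The comparison tests that stereocentre alone, and its reading rests on one fact: the fact that compounds 1 and 3 differ only in the configuration as drawn. The R form does sharpen the comparison of side chains: the exchange of (furan-2-yl)carbonyl for 2-hydroxypropyl gives a 3.6-fold lower number from compound 2 to compound 3 (0.55 log units; beyond the scatter), a modest step beyond the scatter, whereas the exchange with the S form stayed within it (a 2.0-fold higher number from compound 1 to compound 2 (0.30 log units; within the scatter)).

On these data alone, what an amine or a longer chain would do on the same oxygen remains open. So does whether the two configurations would also fall within the scatter of each other on a side chain other than 2-hydroxypropyl.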